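Ether tail replaces carbamoyl on the saturated ring carbon

The source may report more compounds than this note shows. Statements on the series, on what has been measured and on what is new or still open speak of the compounds shown alone.

Compound 3 `Cc1nn(-c2ncnc3nc[nH]c23)c2c1C(C(=O)N(C)c1ccccc1)CC(=O)N2` stands at the top of the three numbers recorded so far: in a functional assay on HEK293 cells for agonist activity at G-protein coupled receptor 39 (Homo sapiens), read by scintillation proximity assay and inositol phosphate accumulation, with a stated time of 75 min, in the presence of a further agent that is not named here (on this read-out lower numbers stand for an effect already at smaller amounts and higher numbers for an effect only at larger amounts of compound), compound 3 gives 32 nM. Compound 1 `Cc1nn(-c2ncnc3nc[nH]c23)c2c1C(OCc1ccc(C#N)cc1)CC(=O)N2` gives 4 nM in this assay, and compound 2 `Cc1nn(-c2ncnc3nc[nH]c23)c2c1C(NC(=O)Cc1cccs1)CC(=O)N2` gives 3 nM; between these two the step is a 1.3-fold lower number from compound 1 to compound 2 (0.12 log units; within the scatter). What sets compound 3 apart are the steps of an 8.0-fold higher number from compound 1 to compound 3 (0.90 log units; beyond the scatter) and an 11-fold higher number from compound 2 to compound 3 (1.03 log units; beyond the scatter), each made on the same saturated ring carbon.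

Compound 4 `Cc1nn(-c2ncnc3nc[nH]c23)c2c1C(OCCn1cccn1)CC(=O)N2` carries 2-(1H-pyrazol-1-yl)ethoxy in place of methyl(phenyl)carbamoyl on a saturated ring carbon. The change removes the carbamoyl that both earlier steps joined to the higher number and restores an oxygen-linked group of the kind carried by compound 1, whose value is 4 nM. Both steps toward compound 3 bear on this change, and both were beyond the scatter in the upward direction. Because of an 8.0-fold higher number from compound 1 to compound 3 (0.90 log units; beyond the scatter) the expectation for compound 4 is a return to a lower number, about a 4.0-fold lower number from compound 3 to compound 4 (0.60 log units; beyond the scatter). Compound 4 is therefore estimated at 8 nM, within a range from 2 nM to 30 nM.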

Compound 4, half-maximal effective concentration: 16 nM
For compound 4 the middle estimate is 2.0-fold (0.30 log units) below the measured one; the measured number falls inside the stated range.
By their numbers in this assay, from the lowest: compounds 2 and 1 (each within the scatter of the next); then compounds 4 and 3 (each within the scatter of the next).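

An oxygen link on the saturated ring carbon does not by itself restore the low number: replacing the carbamoyl with 2-(1H-pyrazol-1-yl)ethoxy gives only (a 2.0-fold lower number from compound 3 to compound 4 (0.30 log units; within the scatter)). Within the ether series the part beyond the oxygen carries the difference, as (1H-pyrazol-1-yl)methyl in place of 4-cyanophenyl gives (a 4.0-fold higher number from compound 1 to compound 4 (0.60 log units; beyond the scatter)). The same pyrazole ether also stays behind the (((thiophen-2-yl)methyl)carbonyl)amino group (a 5.3-fold higher number from compound 2 to compound 4 (0.73 log units; beyond the scatter)), and no measurement at hand accounts for these steps.

Still open, on these data alone, is whether the pyrazole ring or the chain that carries it sets the number of compound 4, which a phenyl ring on the same ethoxy chain would separate. Also open, as far as these compounds go, is how an amine or a carboxylic acid at the end of the ether chain would read out at this position.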